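The source may hold more compounds than are shown below. What is called first, only, known or untested is meant among the compounds shown, and "the series" means these compounds.

Working notes on the series. The read-out throughout is a functional assay on Bel-7402 cells (Homo sapiens) for cytotoxicity, read by MTT assay, with a stated time of 48 h; a lower number here means a stronger inhibitor, a higher number a weaker inhibitor. Compound 1, `CCn1cc(-c2nc3ccccc3[nH]2)c(=O)c2cc(F)c(N3CCNCC3)nc21`, gives 4100 nM in this assay. Compound 2, `CCn1cc(-c2nc3ccccc3[nH]2)c(=O)c2cc(F)c(N3CCNC(C)C3)c(F)c21`, gives 30200 nM in this assay; the difference between its core and that of compound 1 is not broken down here. Among the three measured numbers that of compound 2 is the highest, with compound 3 nearest and compound 1 furthest. Compound 3, `CCn1cc(-c2nc3ccc([N+](=O)[O-])cc3[nH]2)c(=O)c2cc(F)c(N3CCNCC3)nc21`, gives 10800 nM in this assay. The change from compound 1 to compound 3 is nitro in place of hydrogen on an aromatic carbon, and the step it produced is a 2.6-fold higher number from compound 1 to compound 3 (0.42 log units; beyond the scatter), a modest weakening that lies beyond the usual scatter.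

Compound 4, `CCn1cc(-c2nc3ccc([N+](=O)[O-])cc3[nH]2)c(=O)c2cc(F)c(N3CCNC(C)C3)c(F)c21`, has not yet been measured. Among the compounds with values here, it differs from compound 2 by nitro in place of hydrogen on an aromatic carbon, the same change, at the same place on the ring, as the one from compound 1 to compound 3. That change has been seen only once in the series, on the core of compound 1, and nothing shows whether it carries over unchanged to the core of compound 2. Taking the single precedent as the guide, compound 4 is expected to show a 2.6-fold higher number from compound 2 to compound 4 (0.41 log units; beyond the scatter) in this assay, a step of about the same size as the earlier one, because a 2.6-fold higher number from compound 1 to compound 3 (0.42 log units; beyond the scatter) is the only measured occurrence of the change. Compound 4 is therefore estimated at 78000 nM in this assay, with the likely range running from 30000 nM to 200000 nM. Compound 2 already gives the highest number measured, so for compound 4 a reading that is only a limit cannot be ruled out.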

Compound 4, half-maximal inhibitory concentration: 1100 nM
Compound 4: the middle estimate sits 71-fold (1.85 log units) above what was measured, outside the stated range (below it).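

In this assay, nitro in place of hydrogen on an aromatic carbon gives a 27-fold lower number from compound 2 to compound 4 (1.44 log units; beyond the scatter), a large step towards stronger inhibition on the core of compound 2, whereas the same change gave a modest weakening on the core of compound 1. The effect of this change therefore does not carry over from one core to the other in this series, in either size or direction: the same change on two cores in this assay, a 2.6-fold higher number (0.42 log units; beyond the scatter) from compound 1 to compound 3 and a 27-fold lower number (1.44 log units; beyond the scatter) from compound 2 to compound 4, 72-fold (1.86 log units) apart, beyond the scatter of two such steps

Within the data shown here, this rests on only two pairs, and it does not show which feature of the cores goes with the reversal, since compound 1 and compound 2 differ in more than one place and no measured pair separates those differences.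

The compounds shown leave open which single difference between the two cores decides the direction of the step, a question that would need pairs differing at only one of those places. They also leave open whether the reversal belongs to nitro alone or also appears with another group at the same place on the ring, such as a nitrile, an amine or a carboxylic acid.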